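Swapping the methoxy for chloro on compound 1

The source may hold more compounds than are shown below. What is called first, only, known or untested is meant among the compounds shown, and "the series" means these compounds.

Measured compounds in a functional assay on HCT-116 cells (Homo sapiens) for cytotoxicity, read by MTT assay, with a stated time of 72 h; a higher number here means a weaker inhibitor, a lower number a stronger inhibitor:
- compound 1, `COc1ccc(Nc2nc3ccccc3nc2S(=O)(=O)c2ccccc2)cc1`: 2420 nM
- compound 2, `COc1cc(Nc2nc3ccccc3nc2S(=O)(=O)c2ccccc2)cc(OC)c1`: 950 nM
- compound 3, `O=S(=O)(c1ccccc1)c1nc2ccccc2nc1Nc1ccc(F)cc1`: 5190 nM

Among these three numbers compound 1 stands in the middle: compound 2 gives the lowest number, with a 2.5-fold lower number from compound 1 to compound 2 (0.41 log units; beyond the scatter), and compound 3 gives the highest, with a 2.1-fold higher number from compound 1 to compound 3 (0.33 log units; beyond the scatter). Between compound 2 and compound 3 the gap is a 5.5-fold higher number from compound 2 to compound 3 (0.74 log units; beyond the scatter).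

Compound 4, `O=S(=O)(c1ccccc1)c1nc2ccccc2nc1Nc1ccc(Cl)cc1`, is not yet measured. It differs from compound 1 in one place: chloro in place of methoxy on an aromatic carbon.

Within the data shown here, the step that bears most directly on this change is the one from compound 1 to compound 3, where fluoro in place of methoxy on an aromatic carbon gave a 2.1-fold higher number from compound 1 to compound 3 (0.33 log units; beyond the scatter). Chloro is also a halogen entering at the same place, so a similar modest rise in the number is expected in this assay, and nothing among the measured compounds points toward a fall. The step from compound 1 to compound 4 is therefore estimated to be a 1.7-fold higher number from compound 1 to compound 4 (0.24 log units; within the scatter). Compound 4 is expected to give about 4200 nM, with a likely range from 2000 nM to 9000 nM.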

Compound 4, half-maximal inhibitory concentration: 2000 nM
For compound 4 the middle estimate is 2.1-fold (0.32 log units) above the measured one, within the range that was stated.
By their numbers in this assay, from the lowest: compound 2; then compounds 4 and 1 (each within the scatter of the next); then compound 3.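

In this assay, chloro in place of methoxy gives a 1.2-fold lower number from compound 1 to compound 4 (0.08 log units; within the scatter) at this position, so the rise seen with fluoro does not extend to every halogen placed here. Among these compounds, the two halogens are not interchangeable at this position: chloro in place of fluoro gives a 2.6-fold lower number from compound 3 to compound 4 (0.41 log units; beyond the scatter) and so separates two groups that look alike on paper, a difference the earlier compounds could not reveal. The 3,5-dimethoxyphenyl group of compound 2 still keeps its lead over the new group, since 4-chlorophenyl in its place gives a 2.1-fold higher number from compound 2 to compound 4 (0.32 log units; beyond the scatter) and the lowest number in this small set is left unchanged. No evidence is available on what lies behind the gap between chloro and fluoro.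

The compounds shown leave open whether the result at this position follows the size of the halogen, a question that bromo or iodo in the same place would address. They also leave open how an amine, a carboxylic acid or a longer chain such as ethoxy would behave here, and whether chloro would give a similar number on a ring carrying the methoxy groups of compound 2.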